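Methyl on the Outer Phenyl: What Potency to Expect

The source may hold more compounds than are shown below. What is called first, only, known or untested is meant among the compounds shown, and "the series" means these compounds.

Compound 1 `O=c1[nH]cc(S(=O)(=O)Nc2ccccc2-c2cn(-c3ccccc3)nn2)c(=O)[nH]1` gives 6160 nM in a functional assay on HepG2 cells (Homo sapiens) for antiproliferative activity, read by MTT assay, with a stated time of 24 h; a lower number here means a stronger inhibitor, a higher number a weaker inhibitor. Compound 2 `O=c1[nH]cc(S(=O)(=O)Nc2ccccc2-c2cn(-c3ccc(F)cc3)nn2)c(=O)[nH]1` gives only a limit of this assay, > 20000 nM. Compound 3 `O=c1[nH]cc(S(=O)(=O)Nc2cccc(-c3cn(-c4ccccc4)nn3)c2)c(=O)[nH]1` gives 11200 nM.

Among the two numbers, compound 3 stands highest, but its gap to compound 1 is within the scatter, so no order between them can be drawn. Compound 4 `Cc1ccccc1-n1cc(-c2cccc(NS(=O)(=O)c3c[nH]c(=O)[nH]c3=O)c2)nn1` differs from compound 3 by methyl in place of hydrogen on an aromatic carbon. Within the data shown here, the only measured step on that same outer phenyl is an at least 3.2-fold higher number from compound 1 to compound 2 (0.51 log units; beyond the scatter), a weakening, though with a different group. A similar but milder outcome is therefore expected: a 1.4-fold higher number from compound 3 to compound 4 (0.15 log units; within the scatter). Compound 4 is estimated at 16000 nM, between 7000 nM and 40000 nM. Because one value already sits at the limit of > 20000 nM in this assay, at which 1 of the 3 values shown sits, compound 4 may itself return only a limit.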

Compound 4, half-maximal inhibitory concentration: 9570 nM
Estimate against measurement, compound 4: 1.7-fold (0.22 log units) above, and the stated range covers the measured number.
By their numbers in this assay, from the lowest: compounds 1, 4 and 3 (each within the scatter of the next). At a limit, above all of these: compound 2.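

On the outer ring of compound 3, going from phenyl to 2-methylphenyl gives no difference that can be told from the scatter in this assay: a 1.2-fold lower number from compound 3 to compound 4 (0.07 log units; within the scatter). So a methyl ortho to a large group is tolerated here, without the clear loss seen for fluoro in the step to compound 2. Compound 4 returns a number, so the only limit remains that of compound 2: the limit of > 20000 nM in this assay, at which 1 of the 4 values shown sits.

On these data alone, whether an amine, a carboxylic acid or a longer chain at this place would shift the number stays open. So does whether methyl would act the same way on the core of compound 1.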